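Adding a Methyl to the Ethyl Chain of Compound 2

The source may report more compounds than this note shows. Statements on the series, on what has been measured and on what is new or still open speak of the compounds shown alone.

Compound 1 `C#CCSc1nnc(CC)n1N1C(=O)c2ccccc2C1=O`: in a functional assay on PC-3M cells (Homo sapiens) for cytotoxicity, read by MTT assay, with a stated time of 48 h (on this read-out lower numbers stand for stronger inhibition and higher numbers for weaker inhibition), compound 1 gives > 200000 nM, which is a limit of the assay and not a number.
Compound 2 `C=CCSc1nnc(CC)n1N1C(=O)c2ccccc2C1=O`: in this assay compound 2 gives > 200000 nM, again a limit rather than a number.
Compound 3 `CCc1nnc(SCC(=O)c2ccc(Cl)cc2)n1N1C(=O)c2ccccc2C1=O`: in this assay compound 3 gives > 200000 nM, once more a limit.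

Compound 2 therefore stands nowhere in particular on a scale: its result is a limit, and so are both companions, as the limit of > 200000 nM in this assay, at which 3 of the 3 values shown sit, records. The compound not yet measured is compound 4 `C=CCSc1nnc(CCC)n1N1C(=O)c2ccccc2C1=O`, reached from compound 2 by methyl in place of hydrogen on a saturated chain carbon, two bonds along the chain from an aromatic carbon.

Three measured steps exist, and each of them changes the group on the sulfur-bound chain rather than the ethyl chain: a step that the two limits leave unreadable from compound 1 to compound 2, a step that the two limits leave unreadable from compound 1 to compound 3 and a step that the two limits leave unreadable from compound 2 to compound 3. None of them has a readable size, because the limit of > 200000 nM in this assay, at which 3 of the 3 values shown sit, caps all three values at the same point. Within the data shown here, no measured step alters the chain that the new methyl joins, so no direct parallel is available.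

With every neighbour at the limit, the expectation for compound 4 is that the step of a number no higher from compound 2 to compound 4 (the limit leaves the size open) is not readable either, and its value is estimated at 200000 nM, within 80000 nM to 500000 nM, most probably again reported only as a limit.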

Compound 4, half-maximal inhibitory concentration: > 200000 nM
Compound 4: a limit, no number (the forecaster's own chance of this, stated with the estimate: 85%); the middle value lies on the limit itself.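

In this assay compound 4 gives > 200000 nM, which is a limit and not a number. Among these compounds, no step from compound 2 to compound 4 can be read, as both results sit at the same point: the limit of > 200000 nM in this assay, at which 4 of the 4 values shown sit. The compounds shown leave open whether lengthening the ethyl chain to propyl changes this assay at all.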